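This account rests on a few compounds, and the source may have more. Where it says the series, first, only, none or still open, it means among the compounds named here.

Compound 1 `CCCS(=O)(=O)Nc1ccc(F)c(C(=O)c2n[nH]c3ncc(-c4ccccc4Cl)cc23)c1F`: 9.3%
Compound 2 `CCCS(=O)(=O)Nc1ccc(F)c(C(=O)c2n[nH]c3ncc(-c4ccc(F)cc4)cc23)c1F`: 2.1%
Compound 3 `CCCS(=O)(=O)Nc1ccc(F)c(C(=O)c2n[nH]c3ncc(-c4ccc(C)cc4)cc23)c1F`: 5.4%

All three compounds share the same core and differ only in the aryl group carried on the fused ring system. In an assay for binding affinity to dual specificity mitogen-activated protein kinase kinase 4 (Homo sapiens), read by KINOMEscan, tested at 100 nM (on this read-out higher numbers stand for a weaker effect at the one concentration tested and lower numbers for a stronger effect), compound 2 gives the smallest of the three numbers shown, but its gap to each neighbour is small: a number 3.3 percentage points higher from compound 2 to compound 3 (within the scatter), and a number 7.2 percentage points lower from compound 1 to compound 2 (within the scatter). Neither gap exceeds the usual scatter, so nothing separates the three on this read-out.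

Compound 4 `CCCS(=O)(=O)Nc1ccc(F)c(C(=O)c2n[nH]c3ncc(-c4cccc(N)c4)cc23)c1F` has not yet been measured. It is derived from compound 2 by one change: 3-aminophenyl in place of 4-fluorophenyl on an aromatic carbon.

The measured steps that bear on this change are those that also vary the aryl group in the same place. Each of them stayed inside the scatter: a number 7.2 percentage points lower from compound 1 to compound 2 (within the scatter), a number 3.9 percentage points lower from compound 1 to compound 3 (within the scatter), and a number 3.3 percentage points higher from compound 2 to compound 3 (within the scatter). Among the compounds with values here, nothing measured so far shows that exchanging this aryl group moves the read-out beyond the scatter in either direction. Within the data shown here, no step involving an aminophenyl group is available, so the expectation rests only on these three aryl exchanges.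

Compound 4 is therefore expected to give a number close to that of compound 2, with a step of a number 2.9 percentage points higher from compound 2 to compound 4 (within the scatter), that is, no change beyond the scatter. The estimate for compound 4 in this assay is 5%, in a range from 1% to 15%.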

Compound 4, a percentage reported as activity, at one concentration (the size of the read-out at that concentration, not a potency): 1.6%
Compound 4: middle estimate off by 3.4 percentage points, on the high side; measured number inside the range.
By their numbers in this assay, from the lowest: compounds 4, 2, 3 and 1 (each within the scatter of the next).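

In this assay, the position on the shared core now holds a substituent of another kind without any step beyond the scatter: 3-aminophenyl, counted with a hydrogen-bond donor and a hydrogen-bond acceptor, replaces 4-fluorophenyl, counted with neither (a number 0.5 percentage points lower from compound 2 to compound 4 (within the scatter)). The same holds against the other two aryl groups (a number 3.8 percentage points lower from compound 3 to compound 4 (within the scatter); a number 7.7 percentage points lower from compound 1 to compound 4 (within the scatter)), so 2-chlorophenyl, 4-fluorophenyl, 4-methylphenyl and 3-aminophenyl cannot be told apart on this read-out, and the earlier finding now extends from chloro, fluoro and methyl substituents to an amino group. No evidence at hand explains why these four aryl groups give numbers within the scatter of one another.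

Going by these compounds, whether a carboxylic acid or a longer chain on this aryl group, or a saturated ring in place of the phenyl ring, would move the number beyond the scatter remains open. The four compounds are also compared at one concentration only, so any difference in potency among them remains unresolved.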